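The compounds below may be only part of what the source reports. "The series", "measured", "known", "first", "only" and "open" are said of these compounds alone.

Compound 2 `O=C(O)c1ccc(C(=O)/C(=C\c2ccc([N+](=O)[O-])c(O)c2)SCc2ccc(Br)cc2)cc1` and compound 1 `O=C(O)c1ccc(C(=O)/C(=C\c2ccc(O)c([N+](=O)[O-])c2)SCc2ccc(Br)cc2)cc1` share one core. In a functional assay on DU-145 cells (Homo sapiens) for inhibition, read by trypan blue exclusion, with a stated time of 96 h (on this read-out higher numbers stand for weaker inhibition of growth and lower numbers for stronger inhibition of growth), compound 2 gives 10000 nM, while compound 1 gives 50000 nM. The change between them is 4-hydroxy-3-nitrophenyl in place of 3-hydroxy-4-nitrophenyl on a double-bonded chain carbon bound to a double-bonded chain carbon and it produced a 5.0-fold higher number from compound 2 to compound 1 (0.70 log units; beyond the scatter). Compound 3 `O=C(/C(=C\c1ccc([N+](=O)[O-])c(O)c1)Sc1c(F)c(F)c(F)c(F)c1F)c1ccc(Br)cc1` carries a different core; how the cores of compound 3 and compound 2 differ is not broken down here. In this assay compound 3 gives 10000 nM, and compound 3 and compound 2 are level at the digits given. Compound 4 `O=C(/C(=C\c1ccc(O)c([N+](=O)[O-])c1)Sc1c(F)c(F)c(F)c(F)c1F)c1ccc(Br)cc1` has not been measured. For the measured compounds named here, it differs from compound 3 by 4-hydroxy-3-nitrophenyl in place of 3-hydroxy-4-nitrophenyl on a double-bonded chain carbon bound to a double-bonded chain carbon, the same change as the one between compound 2 and compound 1, at the same place. The step is therefore expected to be a 4.0-fold higher number from compound 3 to compound 4 (0.60 log units; beyond the scatter), resting on compound 2 and compound 1 and their a 5.0-fold higher number from compound 2 to compound 1 (0.70 log units; beyond the scatter). Compound 4 is estimated at 40000 nM, between 10000 nM and 160000 nM.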

Compound 4, concentration for 50% growth inhibition: 10000 nM
Beside the measured number, compound 4's estimate is 4.0-fold (0.60 log units) above it, within the range that was stated.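

In this assay, placing 4-hydroxy-3-nitrophenyl in place of 3-hydroxy-4-nitrophenyl gives no change at the digits printed from compound 3 to compound 4 (within the scatter). The change therefore does not carry over at a fixed size between these two cores, and its effect on one core would have misjudged its effect on the other: the same change on two cores in this assay, a 5.0-fold higher number (0.70 log units; beyond the scatter) from compound 2 to compound 1 and no change at the digits printed (within the scatter) from compound 3 to compound 4, 5.0-fold (0.70 log units) apart, beyond the scatter of two such steps This does not show which feature of the two cores separates the results, and two pairs offer no general rule for the series.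

The compounds shown leave open whether a further core would follow the step seen on compound 1 or the one seen on compound 4. They also leave open how the series would respond to a methoxy group or an amine in place of the hydroxyl group on this phenyl ring.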